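This account rests on a few compounds, and the source may have more. Where it says the series, first, only, none or still open, it means among the compounds named here.

Compounds measured so far:
compound 1, `C[C@@H](O)[C@H](NC(=O)CN(c1nc(Cl)nc2[nH]cnc12)C1CC1)C(=O)O`: 37.6%
compound 2, `CC(C)[C@H](NC(=O)CN(c1nc(Cl)nc2[nH]cnc12)C1CC1)C(=O)OCc1ccccc1`: 27.3%

In a functional assay on the whole organism (Tail, strain ICR) with Mus musculus as the target, in the tail flick test, with a stated time of 120 min, at a dose of 25 umol/kg by the oral route (on this read-out higher numbers stand for a stronger effect at the one dose given and lower numbers for a weaker effect), compound 1 stands highest of the two numbers; compound 2 lies a gap below it that is beyond the usual scatter. Compound 3, `O=C(O)C[C@H](NC(=O)CN(c1nc(Cl)nc2[nH]cnc12)C1CC1)C(=O)O`, remains to be measured. It differs from compound 1 by carboxymethyl in place of 1-hydroxyethyl on a saturated chain carbon bound to an amide-type nitrogen and a carbonyl carbon. Among the measured compounds shown here, no step between two measured compounds shows what such a change does, so only a modest lowering, or none beyond the scatter, is expected here. Compound 3 is estimated to give 30% in this assay, within 12% to 48%. The expected step is a number 7.6 percentage points lower from compound 1 to compound 3 (within the scatter).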

Compound 3, a percentage reported as activity, at one dose (the size of the read-out at that dose, not a potency): 22%
Compound 3: middle estimate off by 8 percentage points, on the high side; low and high end bracket the measured number.
By their numbers in this assay, from the lowest: compounds 3 and 2 (each within the scatter of the next); then compound 1.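

In this assay, carboxymethyl in place of 1-hydroxyethyl on a saturated chain carbon bound to an amide-type nitrogen and a carbonyl carbon gives a number 15.6 percentage points lower from compound 1 to compound 3 (beyond the scatter). Among the compounds shown here, this is the first step that can be read at this position, and it shows that the number responds to the group held there, with 1-hydroxyethyl the better of the two. Nothing measured at hand accounts for this step. Still open, as far as these compounds go, is what an aminoethyl group or a longer alkyl chain would give at this place, and whether the step would hold at other doses.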